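Amide to urea at the carbonyl of compound 3

A few compounds are considered here, and "the series" means these few. Any claim that something is new, unique, unknown or untested is made for them only; others in the source may bear on it.

Three measured compounds share one core and differ only in the group on the carbonyl carbon. Compound 1 `COc1ccc(C(=O)NC(CCN(C)C)c2ccc(Cl)cc2)cc1` gives 1350 nM in an assay on NIH3T3 cells with Urotensin-2 receptor (Homo sapiens) as the target; a lower number here means that less compound is needed, a higher number that more compound is needed for the effect. Compound 2 `Cc1ccc(C)c(C(=O)NC(CCN(C)C)c2ccc(Cl)cc2)c1` gives 2880 nM in this assay, and compound 3 `CN(C)CCC(NC(=O)c1ccccc1)c1ccc(Cl)cc1` gives 1410 nM in this assay. Compound 3 stands second highest of the three numbers: its value and that of compound 1 lie within the scatter, a 1.0-fold higher number from compound 1 to compound 3 (0.02 log units; within the scatter), whereas compound 2 sits apart, a 2.0-fold lower number from compound 2 to compound 3 (0.31 log units; beyond the scatter). The remaining step, a 2.1-fold higher number from compound 1 to compound 2 (0.33 log units; beyond the scatter), is of the same modest size.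

Compound 4 `CN(C)CCC(NC(=O)NCc1ccccc1)c1ccc(Cl)cc1` is not yet measured. It differs from compound 3 in that (benzylamino in place of phenyl on a carbonyl carbon). For the measured compounds named here, none of the measured steps makes a change of this kind: each keeps an aromatic ring directly on the carbonyl carbon and alters only its substituents. Going by the values given here, the only guidance is that every change tried at this carbonyl carbon has moved this assay by no more than a 2.0-fold lower number from compound 2 to compound 3 (0.31 log units; beyond the scatter), so a change of similar or somewhat larger scale is expected, with no firm direction. Compound 4 is therefore expected to give 1600 nM in this assay, between 500 nM and 5000 nM. This expected value corresponds to a 1.1-fold higher number from compound 3 to compound 4 (0.05 log units; within the scatter).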

Compound 4, half-maximal effective concentration: 2000 nM
For compound 4 the middle estimate is 1.3-fold (0.10 log units) below the measured one; the range from low to high includes it.
By their numbers in this assay, from the lowest: compounds 1, 3, 4 and 2 (each within the scatter of the next, the first and the last beyond it).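

In this assay, the carbonyl carbon accepts more than an aromatic ring placed directly on it: benzylamino, which brings a nitrogen and a hydrogen-bond donor that phenyl lacks, gives only a 1.4-fold higher number from compound 3 to compound 4 (0.15 log units; within the scatter) in place of phenyl. Measured against the two substituted rings, the reading is the same (a 1.4-fold lower number from compound 2 to compound 4 (0.16 log units; within the scatter) and a 1.5-fold higher number from compound 1 to compound 4 (0.17 log units; within the scatter)), so compound 4 lies within the scatter of all three earlier compounds, even though compound 1 and compound 2 lie beyond the scatter of each other (a 2.1-fold higher number from compound 1 to compound 2 (0.33 log units; beyond the scatter)). No supporting data bear on why the number stays within this narrow band.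

As far as these compounds go, it remains open whether the nitrogen or the methylene of benzylamino matters at all, a question that anilino, phenethylamino or benzyloxy on the same carbonyl carbon could separate. From the compounds shown here alone, it also remains open whether any group at this carbonyl carbon can move the number well beyond the modest steps seen so far, with cyclohexyl, a pyridine ring or a ring bearing a carboxylic acid as untested kinds of change.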